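Swapping 3-bromophenyl for 4-nitrophenyl on a shared core

The source may report more compounds than this note shows. Statements on the series, on what has been measured and on what is new or still open speak of the compounds shown alone.

Compound 1 `O=C(N/N=C/c1ccc([N+](=O)[O-])cc1)Nc1cc2c(Nc3ccc(F)c(Cl)c3)ncnc2cc1O[C@H]1CCOC1` gives 35300 nM
Compound 2 `COc1cc2ncnc(Nc3ccc(F)c(Cl)c3)c2cc1NC(=O)N/N=C/c1cccc(Br)c1` gives "not active" (no number reported)

In a functional assay on HepG2 cells (Homo sapiens) for cytotoxicity, read by MTT assay, with a stated time of 72 h (on this read-out lower numbers stand for stronger inhibition and higher numbers for weaker inhibition), compound 2 is recorded as "not active" (no number reported) and so has no single number to stand on. Compound 3 `COc1cc2ncnc(Nc3ccc(F)c(Cl)c3)c2cc1NC(=O)N/N=C/c1ccc([N+](=O)[O-])cc1` differs from compound 2 by 4-nitrophenyl in place of 3-bromophenyl on a carbon with a double bond to nitrogen and carries 4-nitrophenyl in place of 3-bromophenyl on a carbon with a double bond to nitrogen. Compound 1 also carries 4-nitrophenyl and gives 35300 nM in the same test, a weak but measurable value. Compound 3 is therefore expected to move modestly towards stronger inhibition than compound 2 in this assay and to remain weak, although it too may yield no number. For compound 3 the estimated value is 35000 nM, with an expected range from 12000 nM to 100000 nM.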

Compound 3, half-maximal inhibitory concentration: 34100 nM
Beside the measured number, compound 3's estimate is 1.0-fold (0.01 log units) above it; measured number inside the range.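

In this assay, 4-nitrophenyl on a carbon with a double bond to nitrogen gives a measurable value where 3-bromophenyl does not: compound 3 gives 34100 nM, whereas compound 2 is recorded as "not active" (no number reported), so the size of this step cannot be read. The result also adds a second comparison, a 1.0-fold lower number from compound 1 to compound 3 (0.02 log units; within the scatter), showing that with 4-nitrophenyl in place, methyl and oxolan-3-yl on the oxygen on an aromatic ring give values that cannot be told apart. Nothing measured here explains either observation.

Since 3-bromophenyl and 4-nitrophenyl differ in both substituent and numbered position, the compounds shown cannot separate those two features. Going by these compounds, how 4-bromophenyl, 3-nitrophenyl or 4-aminophenyl would behave at this position remains open.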